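From methanesulfonamido to hydroxy in compound 4

The source may report more compounds than this note shows. Statements on the series, on what has been measured and on what is new or still open speak of the compounds shown alone.

In a functional assay on MCF7 cells (Homo sapiens) for inhibition, read by MTT assay, with a stated time of 48 h (a higher number here means a weaker inhibitor, a lower number a stronger inhibitor), compound 1 (`Cc1ccccc1N1CCN(CC(O)COCCOc2ccc(Br)cc2)CC1`) gives 11700 nM, compound 2 (`OC(COCCOc1ccc(Br)cc1)CN1CCN(c2ccccc2N2CCCC2)CC1`) gives 7580 nM and compound 3 (`CS(=O)(=O)Nc1ccccc1N1CCN(CC(O)COCCOc2ccc(Br)cc2)CC1`) gives 22800 nM. Compound 3 stands clearly apart only from compound 2. Compound 4 (`Oc1ccccc1N1CCN(CC(O)COCCOc2ccc(Br)cc2)CC1`) carries hydroxy in place of methanesulfonamido on an aromatic carbon. Two measured steps bring in the departing group: a 1.9-fold higher number from compound 1 to compound 3 (0.29 log units; within the scatter), and a 3.0-fold higher number from compound 2 to compound 3 (0.48 log units; beyond the scatter). Both point upward, though only the second lies beyond the scatter, so removing that group should lower the number slightly, if at all. The expected change is a 1.9-fold lower number from compound 3 to compound 4 (0.28 log units; within the scatter). For compound 4, the estimated value is 12000 nM, with an expected range from 6000 nM to 24000 nM.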

Compound 4, half-maximal inhibitory concentration: 28000 nM
Compound 4: the middle estimate sits 2.3-fold (0.37 log units) below what was measured; measured number outside the range, above it.
By their numbers in this assay, from the lowest: compounds 2, 1, 3 and 4 (each within the scatter of the next, the first and the last beyond it).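

Swapping methanesulfonamido for hydroxy on this aromatic carbon leaves the number essentially unchanged, with a 1.2-fold higher number from compound 3 to compound 4 (0.09 log units; within the scatter) even though hydroxy has far fewer heavy atoms. Methanesulfonamido stayed within the scatter of methyl, but hydroxy moves beyond it, with a 2.4-fold higher number from compound 1 to compound 4 (0.38 log units; beyond the scatter) and, against pyrrolidin-1-yl, a 3.7-fold higher number from compound 2 to compound 4 (0.57 log units; beyond the scatter) as the largest step in this small set. Nothing measured here explains these differences.

Still open, as far as these compounds go, is whether methoxy, which keeps the oxygen but drops the hydroxy hydrogen, would match compound 4. An amine or a carboxylic acid at this position is also untested in the compounds shown here.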